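Trimming the Side Chain: Cytotoxicity Expected for Compound 4

The compounds below may be only part of what the source reports. "The series", "measured", "known", "first", "only" and "open" are said of these compounds alone.

Of the compounds shown here, three sharing one core have been measured in an ADME assay on HEL cells (Homo sapiens) for cytotoxicity, with a stated time of 3 days; on this read-out lower numbers stand for higher toxicity in this test and higher numbers for lower toxicity in this test. Compound 1 `CCC1(Cc2ccccc2)OS(=O)(=O)C=C1OCc1ccc(Cl)c(Cl)c1` gives 36700 nM. Compound 2 `CCC1(Cc2ccccc2)OS(=O)(=O)C=C1OCc1ccc([N+](=O)[O-])cc1` gives only a limit, < 200000 nM, in this assay. Compound 3 `CCC1(Cc2ccccc2)OS(=O)(=O)C=C1OCCCCc1ccccc1` gives 99000 nM, the highest of the two numbers, with compound 1 as its nearest neighbour: a 2.7-fold higher number from compound 1 to compound 3 (0.43 log units; beyond the scatter). The two steps that involve compound 2, a step that the limit leaves unreadable from compound 1 to compound 2 and a step that the limit leaves unreadable from compound 2 to compound 3, cannot be sized, since they rest on (the limit of < 200000 nM in this assay, at which 1 of the 3 values shown sits).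

The piece now follows the change to compound 4 `C=CCOC1=CS(=O)(=O)OC1(CC)Cc1ccccc1`: vinyl in place of 3-phenylpropyl on a saturated chain carbon bound to an oxygen on an unsaturated carbon. For the measured compounds named here, only one measured step touches the same place, the modest 2.7-fold higher number from compound 1 to compound 3 (0.43 log units; beyond the scatter), and it swaps one aromatic group for another rather than cutting the chain down to two carbons. Going by the values given here, no measured step replaces a phenyl-bearing chain with a short olefin, so the direction of the step is open. Given how small the one comparable step was, a step of similar or smaller size in this assay is expected, and the number is estimated as a 1.1-fold lower number from compound 3 to compound 4 (0.04 log units; within the scatter). Compound 4 is therefore estimated at 90000 nM, with a range from 35000 nM to 230000 nM.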

Compound 4, half-maximal cytotoxic concentration: > 200000 nM
Compound 4 gave a limit, no number; the forecaster's own chance of this, stated with the estimate: 30%; middle value at least 2.2-fold (0.34 log units) from the limit.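

In this assay compound 4 gives > 200000 nM, which is a limit and not a number. Vinyl in place of 3-phenylpropyl removes the six-membered aromatic ring from this group and gives an at least 2.0-fold higher number from compound 3 to compound 4 (0.30 log units; that floor lies within the scatter), so the number does not fall with this change, although the floor of the step alone does not separate it from the scatter. The earlier sized step at this place joined two groups that both carry a ring, whereas the comparison with the dichlorinated compound now gives an at least 5.4-fold higher number from compound 1 to compound 4 (0.73 log units; beyond the scatter), which shows that a group with no ring at this place can stand clearly apart from a ring-bearing one in this test.

Vinyl in place of 4-nitrophenyl gives a number no lower from compound 2 to compound 4 (the limit leaves the size open), and this step cannot be sized, as both compounds give limits: the limit of > 200000 nM in this assay, at which 1 of the 4 values shown sits.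

Ring loss and shortening occur together in compound 4, so the compounds shown leave open which of the two goes with the step, and how an unbranched hexyl chain or a short chain ending in an amine would read at this place.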